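The compounds below may be only part of what the source reports. "The series", "measured", "known", "first", "only" and "open" are said of these compounds alone.

Values in a toxicity assay on J774.A1 cells (Mus musculus) for cytotoxicity, read by SYBR Green assay, with a stated time of 1 h; a lower number here means that less compound is needed, a higher number that more compound is needed for the effect:
- compound 1 `CN(C)c1ccc2cc(-c3ccco3)c(N)nc2c1`: "not determined" (no result reported)
- compound 2 `CNc1ccc2cc(-c3cc(Cl)cc(Cl)c3)c(N)nc2c1`: 3700 nM

Among the measured compounds shown here, compound 2 holds the only number, so it has no measured neighbour to be ranked against. Compound 3 `Nc1nc2cc(N3CCCCC3)ccc2cc1-c1cc(Cl)cc(Cl)c1` puts piperidin-1-yl in place of methylamino on an aromatic carbon of the shared core: piperidin-1-yl in place of methylamino on an aromatic carbon. For the measured compounds named here, no measured pair shows a step of this kind, so no step beyond the scatter is expected in this assay, and no direction is favoured. The expected change is a 1.2-fold lower number from compound 2 to compound 3 (0.09 log units; within the scatter). For compound 3 the estimated value is 3000 nM, with an expected range of 1000 nM to 9000 nM.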

Compound 3, half-maximal effective concentration: 6800 nM
Beside the measured number, compound 3's estimate is 2.3-fold (0.36 log units) below it, and the stated range covers the measured number.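

In this assay, among the compounds shown here, exchanging methylamino for piperidin-1-yl on this aromatic carbon gives a 1.8-fold higher number from compound 2 to compound 3 (0.26 log units; within the scatter), the first measured step at this position. A larger group with a six-membered non-aromatic ring, lacking the hydrogen-bond donor of methylamino, therefore leaves the number within the scatter in this pair. Nothing available explains this result.

As far as these compounds go, whether a carboxylic acid or a longer chain such as n-hexylamino on the same carbon would also stay within the scatter remains open. A single pair also cannot show whether the step holds with another aromatic group on the shared core.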